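The source may hold more compounds than are shown below. What is called first, only, known or untested is meant among the compounds shown, and "the series" means these compounds.

Of the compounds shown here, three built on one shared core have been tested in a functional assay on Shh Light II cells (Mus musculus) for inhibition, read by a luciferase reporter; on this read-out higher numbers stand for weaker inhibition and lower numbers for stronger inhibition. Compound 1 `O=C(NC1CCNCC1)N1CCC(c2nc(-c3ccc4ccccc4n3)no2)CC1` gives 2500 nM in this assay. Compound 2 `CC(C)c1ccccc1NC(=O)N1CCC(c2nc(-c3ccc4ccccc4n3)no2)CC1` gives 480 nM. Compound 3 `O=C(NC1CCC(O)CC1)N1CCC(c2nc(-c3ccc4ccccc4n3)no2)CC1` gives 2700 nM, the highest of the three numbers; a 1.1-fold higher number from compound 1 to compound 3 (0.03 log units; within the scatter) lies within the scatter, whereas a 5.6-fold higher number from compound 2 to compound 3 (0.75 log units; beyond the scatter) lies beyond it. Compound 4 `O=C(Nc1cccnc1Cl)N1CCC(c2nc(-c3ccc4ccccc4n3)no2)CC1` has not yet been measured. It differs from compound 3 in one place: 2-chloropyridin-3-yl in place of 4-hydroxycyclohexyl on an amide-type nitrogen. Going by the values given here, two measured steps bear on this change, since each exchanges a non-aromatic ring for an aromatic one, or the reverse, on the same amide-type nitrogen: a 5.2-fold lower number from compound 1 to compound 2 (0.72 log units; beyond the scatter) and a 5.6-fold higher number from compound 2 to compound 3 (0.75 log units; beyond the scatter). In both, the compound carrying the aromatic ring showed the lower number. A modest lowering is therefore expected here too, with some caution, as a different aromatic ring enters and only compound 2 provides an aromatic example. The step is estimated as a 3.9-fold lower number from compound 3 to compound 4 (0.59 log units; beyond the scatter). Compound 4 is expected to give about 700 nM in this assay, within a range from 250 nM to 2000 nM.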

Compound 4, half-maximal inhibitory concentration: 1600 nM
Beside the measured number, compound 4's estimate is 2.3-fold (0.36 log units) below it; the measured number falls inside the stated range.
By their numbers in this assay, from the lowest: compound 2; then compounds 4, 1 and 3 (each within the scatter of the next).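

In this assay, an aromatic ring on the amide-type nitrogen does not by itself bring stronger inhibition: 2-chloropyridin-3-yl gives a 1.7-fold lower number from compound 3 to compound 4 (0.23 log units; within the scatter) and a 1.6-fold lower number from compound 1 to compound 4 (0.19 log units; within the scatter), so it does not separate from either non-aromatic group. The identity of the aromatic ring does matter at this position, as replacing 2-isopropylphenyl with 2-chloropyridin-3-yl gives a 3.3-fold higher number from compound 2 to compound 4 (0.52 log units; beyond the scatter) and weakens inhibition. Compound 2 therefore remains the strongest inhibitor of the four, and the earlier link between an aromatic ring and a lower number now rests on compound 2 alone, with compound 4 going against it.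

The two aromatic groups differ in both ring atoms and substituent, so a plain phenyl or a 2-chlorophenyl group would be needed to tell these differences apart. No measurement shown gives a cause for the gap between them.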